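This account rests on a few compounds, and the source may have more. Where it says the series, first, only, none or still open, it means among the compounds named here.

Compound 2 `O=C1C[C@H](O)C[C@@H](/C=C/c2c(Cl)cc(Cl)cc2CCc2ccccc2)O1` and compound 1 `Cc1ccc(-c2cc(Cl)cc(Cl)c2/C=C/[C@@H]2C[C@@H](O)CC(=O)O2)cc1` share one core and differ only in the group on the aromatic carbon. Among the compounds with values here, in an assay for inhibition of 3-hydroxy-3-methylglutaryl-coenzyme A reductase (Rattus norvegicus) (a lower number here means a stronger inhibitor, a higher number a weaker inhibitor), compound 1 gives 190 nM, and compound 2 gives 430 nM; the step of a 2.3-fold higher number from compound 1 to compound 2 (0.35 log units; beyond the scatter) is the only measured change, and it leaves compound 2 with the higher number of the two. Compound 3 `CCc1cccc(-c2cc(Cl)cc(Cl)c2/C=C/[C@@H]2C[C@@H](O)CC(=O)O2)c1` is not yet measured; the change is 3-ethylphenyl in place of phenethyl on an aromatic carbon. The step to compound 3 is not the reverse of the measured one, since 3-ethylphenyl is neither phenethyl nor 4-methylphenyl, yet it returns to an aromatic ring sitting directly on the core, as in compound 1. Within the data shown here, the single step available argues that a directly attached ring lowers the number in this assay. Compound 3 is therefore expected to move by a 1.7-fold lower number from compound 2 to compound 3 (0.24 log units; within the scatter), toward compound 1, with the estimate 250 nM and a range from 100 nM to 600 nM.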

Compound 3, half-maximal inhibitory concentration: 44 nM
Beside the measured number, compound 3's estimate is 5.7-fold (0.75 log units) above it, outside the stated range (below it).
By their numbers in this assay, from the lowest: compound 3; then compound 1; then compound 2.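

Within this assay, phenethyl and 3-ethylphenyl have the same atoms joined differently, yet the exchange gives a 9.8-fold lower number from compound 2 to compound 3 (0.99 log units; beyond the scatter), so at this position the number follows how those atoms are arranged and not just their composition. Direct attachment of a ring does not alone set the number, as the two directly attached groups also separate: 3-ethylphenyl in place of 4-methylphenyl gives a 4.3-fold lower number from compound 1 to compound 3 (0.64 log units; beyond the scatter). Nothing available accounts for either step.

The step from 4-methylphenyl to 3-ethylphenyl alters both the alkyl group and its place on the ring, and the compounds shown do not divide the change between the two. A 3-methylphenyl or 4-ethylphenyl group on this carbon would separate them, while a 3-propylphenyl group would test a longer chain.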